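The source may report more compounds than this note shows. Statements on the series, on what has been measured and on what is new or still open speak of the compounds shown alone.

Compound 1 `C/C(=C\c1cc(-c2ccccc2)co1)C(N)=O` and compound 2 `C/C(=C\c1cc(-c2ccc(C)cc2)co1)C(N)=O` share one core; compound 3 `C/C(=C\c1cccc(-c2ccccc2)c1)C(N)=O` and the unmeasured compound 4 `C/C(=C\c1cccc(-c2ccc(C)cc2)c1)C(N)=O` share another, and the difference between the two cores is not broken down here. Within each pair the same change is made: methyl in place of hydrogen on an aromatic carbon and (methyl in place of hydrogen on an aromatic carbon). In a functional assay on BGC-823 cells (Homo sapiens) for cytotoxicity, read by CCK-8 assay, with a stated time of 24 h (a higher number here means a weaker inhibitor, a lower number a stronger inhibitor), compound 1 gives > 50000 nM, a limit of the assay rather than a number. In this assay compound 2 gives > 50000 nM, again a limit. In this assay compound 3 gives > 50000 nM, also a limit. The step that the two limits leave unreadable from compound 1 to compound 2 therefore cannot be read, and every measured value sits at the limit of > 50000 nM in this assay, at which 3 of the 3 values shown sit. The expected step is a step that the limit leaves unreadable from compound 3 to compound 4, resting on a step that the two limits leave unreadable from compound 1 to compound 2 and on (the limit of > 50000 nM in this assay, at which 3 of the 3 values shown sit). Compound 4 is accordingly expected to give 80000 nM, most likely reported as a limit once more, with a range from 40000 nM to 200000 nM.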

Compound 4, half-maximal inhibitory concentration: > 50000 nM
Compound 4 gave a limit, no number; the forecaster's own chance of this, stated with the estimate: 90%; the middle value lies beyond the limit too.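

Compound 3 and compound 4 both give only a limit in this assay, so no new step can be read between them: the limit of > 50000 nM in this assay, at which 4 of the 4 values shown sit.
The compounds shown leave open whether methyl in place of hydrogen on an aromatic carbon changes cytotoxicity at all.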